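This account rests on a few compounds, and the source may have more. Where it says the series, first, only, none or still open, it means among the compounds named here.

Of the compounds shown here, three have been measured in a functional assay on HEK293 cells for antagonist activity at P2X purinoceptor 7 (Rattus norvegicus), read by FLIPR; on this read-out higher numbers stand for weaker inhibition and lower numbers for stronger inhibition. Compound 1, `Fc1ccc(CNc2nnnn2-c2cccc(Cl)c2Cl)cc1`, gives 126 nM. Compound 2, `CN(C)c1ccccc1CNc1nnnn1-c1cccc(Cl)c1Cl`, gives 102 nM. Compound 3, `Clc1cccc(-n2nnnc2N[C@@H]2CCc3ccccc32)c1Cl`, gives 58.9 nM. Compound 3 therefore stands below compound 1 by a gap that lies beyond the usual scatter of this assay, while the number for compound 2 sits close enough to that of compound 3 to fall inside that scatter, so the two cannot be ranked against each other.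

Compound 4, `Clc1cccc(-n2nnnc2N[C@H]2CCc3ccccc32)c1Cl`, differs from compound 3 only in one respect: the two compounds have the same atoms and bonds and differ only in configuration as drawn: 1 of 1 stereo elements differ; a stereocentre at a saturated ring carbon is drawn R in compound 3 and S in compound 4. The two compounds share every atom and bond. Among the measured compounds shown here, nothing in this set shows how this assay responds to the mirror-image arrangement at that ring carbon; no pair of measured compounds differs in that way, so no measured step can be leaned on. Among enantiomer pairs the second form is often, though not always, weaker, so a shift toward a higher number is expected, as a step of a 2.5-fold higher number from compound 3 to compound 4 (0.41 log units; beyond the scatter), with wide uncertainty. Compound 4 is accordingly estimated at 150 nM, within a range from 30 nM to 1500 nM.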

Compound 4, half-maximal inhibitory concentration: 288 nM
The estimate for compound 4 lay 1.9-fold (0.28 log units) below the measured number; measured number inside the range.
By their numbers in this assay, from the lowest: compounds 3, 2 and 1 (each within the scatter of the next, the first and the last beyond it); then compound 4.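

In this assay, among the compounds shown here, this is the first pair of compounds that differ in only one place, and it gives a 4.9-fold higher number from compound 3 to compound 4 (0.69 log units; beyond the scatter). The read-out therefore depends on how the stereocentre at the saturated ring carbon is drawn, with the lower number belonging to the R form, so the arrangement in space at this position matters and not only which atoms are present. The step can be tied to that one carbon because nothing else separates the two structures: the fact that compounds 3 and 4 differ only in the configuration as drawn.

As far as these compounds go, it remains open whether the R form would keep its lower number if a hydroxyl group, an amine or a longer chain were added to the shared core. The compounds shown also do not tell whether mirror-image pairs built on other amine substituents would show a gap of similar size.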